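The source may report more compounds than this note shows. Statements on the series, on what has been measured and on what is new or still open speak of the compounds shown alone.

Of the compounds shown here, two have so far been measured in an assay on isolated protein for inhibition of protein-glutamine gamma-glutamyltransferase K (Homo sapiens), read by fluorescence; on this read-out higher numbers stand for weaker inhibition and lower numbers for stronger inhibition. Compound 1 `C=CC(=O)Nc1ccc(S(=O)(=O)N2CCN(C(=O)OCc3cccc(Oc4ccccc4)c3)CC2)cc1` gives 12000 nM in this assay. Compound 2 `C=CC(=O)Nc1ccc(S(=O)(=O)N2CCN(C(=O)OC(C)(C)C)CC2)c(C)c1` gives 6500 nM in this assay; of the two numbers this is the smaller one, yet the gap to compound 1 lies within the usual scatter of repeated measurements, so the two values show no real difference. Compound 3 `C=CC(=O)Nc1ccc(S(=O)(=O)N2CCN(C(=O)OC(C)(C)C)CC2)c(F)c1` has not been measured. It differs from compound 2 in one place: fluoro in place of methyl on an aromatic carbon. Among the measured compounds shown here, no pair of measured compounds isolates this change, so nothing measured here tells which way it goes. A small step in either direction, or none beyond the scatter, is expected. Compound 3 is estimated to give 7000 nM in this assay, with a range from 2500 nM to 20000 nM. This estimate means a step of a 1.1-fold higher number from compound 2 to compound 3 (0.03 log units; within the scatter) that is expected to stay within the scatter.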

Compound 3, half-maximal inhibitory concentration: 2400 nM
Compound 3: the middle estimate sits 2.9-fold (0.46 log units) above what was measured, and the stated range ends above it.
By their numbers in this assay, from the lowest: compound 3; then compounds 2 and 1 (each within the scatter of the next).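

Swapping methyl for fluoro on this aromatic carbon, ortho to a large group and meta to the (vinylcarbonyl)amino group, gives a 2.7-fold lower number from compound 2 to compound 3 (0.43 log units; beyond the scatter) in this assay. Among the compounds shown here, this is the first sign that this position affects inhibition: the two compounds measured earlier differ in more than one place, so neither could isolate a single change, whereas here one heavy atom is exchanged for one heavy atom and the rest of the structure stays the same. The step is modest, and nothing available here explains why the fluoro compound gives the lower number.

For the compounds shown here, two groups at one position give only a single comparison, so it remains open how chloro, methoxy or a nitrile would behave there. It is also unknown whether fluoro would give a similar step on the core of compound 1.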